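The source may hold more compounds than are shown below. What is called first, only, known or untested is meant among the compounds shown, and "the series" means these compounds.

Compound 1, `CN(Cc1ccc(Cl)cc1)Cc1ccccc1CNc1ccnc2cc(Cl)ccc12`: in a physicochemical assay for acid dissociation, compound 1 gives 9.6.
Compound 2, `CN(Cc1ccccc1)Cc1ccccc1CNc1ccnc2cc(Cl)ccc12`: in this assay compound 2 gives 9.85.
Compound 3, `CN(Cc1ccc(Cl)cc1)Cc1ccc(CNc2ccnc3cc(Cl)ccc23)cc1`: in this assay compound 3 gives 9.74.

All three measured compounds share a chlorine-bearing bicyclic core joined through a linker to a benzylic amine, and the three values in this assay lie close to one another. Compound 1 and compound 2 differ in one place: hydrogen in place of chloro on an aromatic carbon. This change gave a number 0.25 log units higher from compound 1 to compound 2 (within the scatter), a step that stays inside the usual scatter of the measurement.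

Compound 3 is built from the same atoms as compound 1, joined differently; the difference between the two cores is not broken down here. Compound 4, `CN(Cc1ccccc1)Cc1ccc(CNc2ccnc3cc(Cl)ccc23)cc1`, has not yet been measured. It stands to compound 3 exactly as compound 2 stands to compound 1: hydrogen in place of chloro on an aromatic carbon. The place of the change reads the same in both pairs. It is the same change, made on the core of compound 3 instead of the core of compound 1.

The expectation for compound 4 therefore rests on a single earlier example. Since compound 3 gives 9.74 and the same change once produced a number 0.25 log units higher from compound 1 to compound 2 (within the scatter), compound 4 is expected to come out at 9.95 in this assay, between 9.6 and 10.3. This estimate means a step of a number 0.21 log units higher from compound 3 to compound 4 (within the scatter), again expected to fall within the scatter.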

Compound 4, acid dissociation constant: 9.9
For compound 4 the middle estimate is 0.05 log units above the measured one, within the range that was stated.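

In this assay, putting hydrogen in place of chloro on the core of compound 3 gave a number 0.16 log units higher from compound 3 to compound 4 (within the scatter), while the same change on the core of compound 1 gave a number 0.25 log units higher from compound 1 to compound 2 (within the scatter), so on both cores the step stays within the usual scatter of repeated measurements. This shows that, for these two pairs, moving the change from one core to the other made no difference that this measurement can resolve, but two pairs are a small sample, and steps inside the scatter cannot establish that the change has a real effect of a fixed size that travels between cores. The data shown offer no independent evidence that could explain these readings.

In the compounds shown, the place of the change holds only chloro or hydrogen, so it remains open whether a larger swap there, such as a methoxy group, a carboxylic acid or an amine, would also give matching steps on the two cores. As far as these compounds go, it also remains open whether the replacement of chloro by hydrogen would read the same way on a third core, for example one with a longer chain in its linker.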